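Sulfonamide hydroxamates: compound 3 to compound 4

The compounds below may be only part of what the source reports. "The series", "measured", "known", "first", "only" and "open" are said of these compounds alone.

Three members of the series have been measured in an assay on isolated protein for inhibition of bone morphogenetic protein 1 (Homo sapiens); a higher number here means a weaker inhibitor, a lower number a stronger inhibitor. Compound 1 `COc1ccc(S(=O)(=O)N(Cc2ccc(Cl)c([N+](=O)[O-])c2)[C@H](C)C(=O)NO)cc1` gives 30 nM, compound 2 `COc1ccc(S(=O)(=O)N(Cc2sc3scc(C)c3c2C)[C@H](C)C(=O)NO)cc1` gives 60 nM, and compound 3 `COc1ccc(S(=O)(=O)N(CCn2cccc2)[C@H](C)C(=O)NO)cc1` gives 170 nM. Compound 3 thus stands at the highest number of the three; its nearest neighbour is compound 2, and the gap to compound 1 is wider still, both gaps lying beyond the usual scatter of this assay.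

The next compound, compound 4 `COc1ccc(S(=O)(=O)N(Cc2ccc(Br)cc2)[C@H](C)C(=O)NO)cc1`, is reached from compound 3 by a single change: 4-bromophenyl in place of (1H-pyrrol-1-yl)methyl on a saturated chain carbon bound to a sulfonamide nitrogen. Among the compounds with values here, no measured pair isolates exactly this change, so any expectation rests on the spread of the three numbers alone. Compound 4 is expected to sit at 50 nM, within a range from 20 nM to 130 nM, because compound 1 at 30 nM and compound 2 at 60 nM both give lower numbers than compound 3 in this assay. The expected step of a 3.4-fold lower number from compound 3 to compound 4 (0.53 log units; beyond the scatter) therefore points downward and beyond the scatter, though with a wide margin.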

Compound 4, half-maximal inhibitory concentration: 37 nM
Compound 4: middle estimate off by 1.4-fold (0.13 log units), on the high side; the measured number falls inside the stated range.
By their numbers in this assay, from the lowest: compounds 1, 4 and 2 (each within the scatter of the next); then compound 3.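

In this assay, the series now has its first single-change step at this position: a 4.6-fold lower number from compound 3 to compound 4 (0.66 log units; beyond the scatter), with 4-bromophenyl in place of (1H-pyrrol-1-yl)methyl on a saturated chain carbon bound to a sulfonamide nitrogen. The step lies beyond the scatter, so the group carried at this position measurably changes the number, and this one swap gives a stronger inhibitor. Nothing available explains the size or direction of this step.

The swap alters the ring, the bromine and the chain together, so the pair cannot assign the step to any one of them. Also open, as far as these compounds go, is how an amine or a carboxylic acid in place of the bromine of 4-bromobenzyl would read, as would a longer chain ahead of the 4-bromophenyl ring.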